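A few compounds are considered here, and "the series" means these few. Any claim that something is new, unique, unknown or untested is made for them only; others in the source may bear on it.

In an ADME assay on BJ cells (Homo sapiens) for cytotoxicity, read by MTT assay, with a stated time of 72 h (a higher number here means that more compound is tolerated, a lower number that less compound is tolerated), compound 1 (`OC[C@H]1O[C@@H](n2cc(F)c3c(-c4cccs4)ncnc32)[C@H](O)[C@@H]1O`) gives 170 nM while compound 2 (`OC[C@H]1O[C@@H](n2cc(Cl)c3c(-c4ccccc4)ncnc32)[C@H](O)[C@@H]1O`) gives 44500 nM and compound 3 (`OC[C@H]1O[C@@H](n2cc(Cl)c3c(-c4ccco4)ncnc32)[C@H](O)[C@@H]1O`) gives 37300 nM in the same test. Compound 3 therefore sits level with compound 2 within the scatter, and both lie far from compound 1, a gap well beyond the scatter. The next compound is compound 4 (`OC[C@H]1O[C@@H](n2cc(Cl)c3c(-c4cccs4)ncnc32)[C@H](O)[C@@H]1O`), which carries thiophen-2-yl in place of furan-2-yl on an aromatic carbon and keeps the chlorine of compound 3. Among the measured compounds shown here, only one measured step bears directly on such an exchange: a 1.2-fold lower number from compound 2 to compound 3 (0.08 log units; within the scatter) for furan-2-yl in place of phenyl, which shows no change at this carbon. Against that stands compound 1 at 170 nM as the only measured compound with thiophen-2-yl, though it carries fluorine where compound 4 carries chlorine. For the measured compounds named here, no measured pair separates the halogen from the ring, so the weight of each remains unknown. The two indications are therefore split, and an expected 15-fold lower number from compound 3 to compound 4 (1.17 log units; beyond the scatter) is taken as a downward move beyond the scatter, of uncertain size. For compound 4 the estimated value is 2500 nM with an expected range from 300 nM to 25000 nM around it.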

Compound 4, half-maximal cytotoxic concentration: 4970 nM
Compound 4: middle estimate off by 2.0-fold (0.30 log units), on the low side; low and high end bracket the measured number.
By their numbers in this assay, from the lowest: compound 1; then compound 4; then compounds 3 and 2 (each within the scatter of the next).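

In this assay, with the chlorine held fixed, the choice of ring on this aromatic carbon now proves to matter. Furan-2-yl and phenyl had stood level (a 1.2-fold lower number from compound 2 to compound 3 (0.08 log units; within the scatter)), yet thiophen-2-yl gives a 7.5-fold lower number from compound 3 to compound 4 (0.88 log units; beyond the scatter) and a 9.0-fold lower number from compound 2 to compound 4 (0.95 log units; beyond the scatter), so exchanging oxygen for sulfur in a five-membered aromatic ring moves the number beyond the scatter. With thiophen-2-yl held fixed, the halogen turns out to carry the larger step, a 29-fold higher number from compound 1 to compound 4 (1.47 log units; beyond the scatter), so thiophen-2-yl alone does not account for the very low number of compound 1, and nothing measured here gives a reason for either step.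

The compounds shown leave open whether the exchange of chloro for fluoro would have a similar size with phenyl or furan-2-yl on this carbon, so the two changes cannot yet be treated as independent. They also leave open how bromo would compare in place of the halogen, and how an amine or a methyl group would compare in place of the ring.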